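The source may report more compounds than this note shows. Statements on the series, on what has been measured and on what is new or still open speak of the compounds shown alone.

Of the compounds shown here, three built on one shared core have so far been tested in a functional assay on HCT-116 cells (Homo sapiens) for cytotoxicity, read by MTT assay, with a stated time of 48 h; a higher number here means a weaker inhibitor, a lower number a stronger inhibitor. Compound 1 `O=C(/C=C\Nc1ccc2cc[nH]c2c1)c1nc(-c2ccc(C(F)(F)F)cc2)n2ccccc12` carries an indolyl group on its amine nitrogen. In this assay compound 1 gives > 30000 nM, which is a limit of the assay and not a measured number. Compound 2 `O=C(/C=C\Nc1cnc2ccccc2c1)c1nc(-c2ccccc2)n2ccccc12` gives > 30000 nM, again only a limit. Compound 3 `COc1ccc(N/C=C\C(=O)c2nc(-c3ccc(F)cc3)n3ccccc23)cc1OC` likewise gives > 30000 nM, a limit as well. The common thread is the limit of > 30000 nM in this assay, at which 3 of the 3 values shown sit, so compound 1 stands level with the other two at the edge of what the assay can report, and nothing separates the three from one another.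

Compound 4 `COc1ccc(N/C=C\C(=O)c2nc(-c3ccc(C(F)(F)F)cc3)n3ccccc23)cc1` differs from compound 1 in one place: 4-methoxyphenyl in place of 1H-indol-6-yl on an amine nitrogen. Compound 3, whose amine nitrogen also carries a methoxy-substituted phenyl, gives > 30000 nM in this assay, a limit with no number beneath it. Within the data shown here, with that in view, the step of a number no higher from compound 1 to compound 4 (the limit leaves the size open) is expected to be none beyond the usual scatter, and most likely no step at all that the assay can resolve. Compound 4 is therefore expected to give about 30000 nM, somewhere between 10000 nM and 100000 nM, and quite probably to be reported once more only as a limit.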

Compound 4, half-maximal inhibitory concentration: 7720 nM
Compound 4: the middle estimate sits 3.9-fold (0.59 log units) above what was measured; the whole stated range lies above it.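

In this assay, 4-methoxyphenyl in place of 1H-indol-6-yl on the amine nitrogen gives an at least 3.8-fold lower number from compound 1 to compound 4 (0.58 log units; beyond the scatter), so the group at this position can move cytotoxicity from beyond what the assay reports to a value it can measure. The size of this step is only a minimum, as the starting point is a limit and not a number. Compound 4 is also the only compound shown with a real number, which gives the series its first measured reference point: the limit of > 30000 nM in this assay, at which 3 of the 4 values shown sit.

The swap changes several things at once, replacing a two-ring group with a single ring, removing a hydrogen-bond donor and adding a hydrogen-bond acceptor, so this one step cannot show which of these differences matters. Placing a 4-ethoxyphenyl, a 4-hydroxyphenyl or a 4-aminophenyl group on the same amine nitrogen, with the rest of compound 4 unchanged, would test whether the methoxy group itself counts and whether a longer chain or a different atom at that spot is tolerated.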